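This account rests on a few compounds, and the source may have more. Where it says the series, first, only, none or still open, it means among the compounds named here.

Compound 1 `COc1cc(-c2nnc3n2NC(c2ccco2)C(C(=O)c2ccc(F)c(F)c2)S3)cc(OC)c1OC`: in a functional assay on A549 cells (Homo sapiens) for cytotoxicity, read by MTT assay, with a stated time of 48 h (a higher number here means a weaker inhibitor, a lower number a stronger inhibitor), compound 1 gives 93700 nM.
Compound 2 `COc1cc(-c2nnc3n2NC(c2ccco2)C(C(=O)c2cccs2)S3)cc(OC)c1OC`: in this assay compound 2 gives 78700 nM.
Compound 3 `COc1cc(-c2nnc3n2NC(c2ccco2)C(C(=O)c2ccc(-c4ccccc4)cc2)S3)cc(OC)c1OC`: in this assay compound 3 gives only a limit, > 100000 nM.

Compound 3 thus stands at the edge of what this assay reports (the limit of > 100000 nM in this assay, at which 1 of the 3 values shown sits), so only a floor is known for it. Compound 4 `COc1cc(-c2nnc3n2NC(c2ccco2)C(C(=O)c2cccc4ccccc24)S3)cc(OC)c1OC` differs from it in one place: naphthalen-1-yl in place of 4-phenylphenyl on a carbonyl carbon. For the measured compounds named here, the steps that bear on this are an at least 1.0-fold higher number from compound 1 to compound 3 (0.02 log units; that floor lies within the scatter) and an at least 1.2-fold higher number from compound 2 to compound 3 (0.10 log units; that floor lies within the scatter), both within the scatter, as is a 1.2-fold lower number from compound 1 to compound 2 (0.08 log units; within the scatter). Every change at this carbonyl carbon has so far left the number where it was, so no step beyond the scatter is expected, and compound 4 is estimated to fall again at or near the limit, a number no higher from compound 3 to compound 4 (the limit leaves the size open). Compound 4 is therefore estimated at 100000 nM, between 50000 nM and 200000 nM.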

Compound 4, half-maximal inhibitory concentration: > 100000 nM
Compound 4 was reported as a limit; the forecaster's own chance of this, stated with the estimate: 55%; the middle value sits exactly at the limit.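

Compound 4 joins compound 3 as a second compound with two six-membered aromatic rings on this carbonyl carbon to be reported only as a limit in this assay: the limit of > 100000 nM in this assay, at which 2 of the 4 values shown sit. The comparisons with the measured compounds give an at least 1.2-fold higher number from compound 2 to compound 4 (0.10 log units; that floor lies within the scatter) and an at least 1.0-fold higher number from compound 1 to compound 4 (0.02 log units; that floor lies within the scatter), so neither floor separates compound 4 from them. The step between the two limits cannot be read, so 4-phenylphenyl and naphthalen-1-yl cannot be ranked.

Going by these compounds, it remains open whether a carboxylic acid or an amine at this carbonyl carbon would move the number beyond the scatter.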